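One Side Group Changes on a Shared Core

A few compounds are considered here, and "the series" means these few. Any claim that something is new, unique, unknown or untested is made for them only; others in the source may bear on it.

Within the data shown here, two related compounds have numbers so far in a functional assay on DU-145 cells (Homo sapiens) for cytotoxicity, read by MTT assay, with a stated time of 72 h; on this read-out higher numbers stand for an effect only at larger amounts of compound and lower numbers for an effect already at smaller amounts. Compound 1 (`CCc1cccc2c(O)c(-c3occ(C)c3C(=O)O)ccc12`) gives 8.7 ug/mL, and compound 2 (`CCOC(=O)c1c(C)coc1-c1ccc2c(CC)cccc2c1OC`) gives 2.2 ug/mL. Compound 2 therefore holds the lower of the two numbers, so it shows its effect at the smaller amount, and its gap to compound 1 lies beyond the usual scatter of repeated measurements. These two compounds differ in more than one place, so their gap cannot be tied to any single group.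

Compound 3 (`CCc1cccc2c(OC)c(-c3occ(C)c3C(=S)OC)ccc12`) has not been measured yet. It differs from compound 2 in one place: a group of 4 heavy atoms (2 carbon, 1 oxygen, 1 sulfur; no ring) in place of a group of 5 heavy atoms (3 carbon, 2 oxygen; no ring), on an aromatic carbon. The change sits on an aromatic carbon of a five-membered aromatic ring with 1 oxygen. Among the measured compounds shown here, no measured pair shows what a change of this kind does, so the expectation is cautious. The expected step of a 1.1-fold higher number from compound 2 to compound 3 (0.06 log units; within the scatter) stays within the scatter, with no firm direction. In this assay, compound 3 is estimated at 2.5 ug/mL, with an expected range of 0.8 ug/mL to 7 ug/mL.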

Compound 3, concentration for half-maximal effect: 5.7 ug/mL
Compound 3: the middle estimate sits 2.3-fold (0.36 log units) below what was measured, and the stated range covers the measured number.
By their numbers in this assay, from the lowest: compound 2; then compounds 3 and 1 (each within the scatter of the next).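

Among these compounds, the swap of the ethoxycarbonyl group for the sulfur-bearing group of 4 heavy atoms produces a 2.6-fold higher number from compound 2 to compound 3 (0.41 log units; beyond the scatter) in this assay, and it is the first comparison here that isolates a single place on the shared core. It shows that this aromatic carbon of the five-membered aromatic ring with 1 oxygen is not a silent spot: with the ring count, the double bond outside aromatic rings and the counts of hydrogen-bond donors and acceptors all unchanged, the number still moves beyond the scatter, towards needing more compound for the same effect. No measurement among those shown explains why the number moves in this direction.

This one swap changes two things at once, an oxygen exchanged for sulfur and a shorter group overall, and the compounds shown do not tell these two apart. A methoxycarbonyl group at this place would separate them, and a primary amide would show whether a group with a hydrogen-bond donor fits the same trend.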